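A Methoxy Added to the Strongest Binder in the Set

The compounds below may be only part of what the source reports. "The series", "measured", "known", "first", "only" and "open" are said of these compounds alone.

In an assay on membranes from brain (Cavia porcellus) for binding affinity to Sigma non-opioid intracellular receptor 1 (Homo sapiens), read by radioligand binding (on this read-out lower numbers stand for stronger inhibition and higher numbers for weaker inhibition), compound 1 `O=C(Cc1ccccn1)NC1CCN(Cc2ccccc2)CC1` gives 236 nM and compound 2 `O=C(Cc1ccncc1)NC1CCN(Cc2ccccc2)CC1` gives 298 nM; a 1.3-fold higher number from compound 1 to compound 2 (0.10 log units; within the scatter). Compound 3 `O=C(Cc1c[nH]c2ccccc12)NC1CCN(Cc2ccccc2)CC1` gives 10.9 nM in this assay, the lowest of the three numbers and beyond the scatter from both others, so it stands as the strongest binder measured. Compound 4 `COc1ccc2[nH]cc(CC(=O)NC3CCN(Cc4ccccc4)CC3)c2c1` carries methoxy in place of hydrogen on an aromatic carbon. None of the measured steps touches this part of compound 3; the single step shown concerns the pyridinyl group and lies within the scatter. The chemist therefore expects compound 4 to show no change beyond the scatter in this assay, a 1.0-fold higher number from compound 3 to compound 4 (0.00 log units; within the scatter). The estimate for compound 4 is 11 nM, with a range from 3.5 nM to 35 nM.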

Compound 4, inhibition constant: 125 nM
Compound 4: the middle estimate sits 11-fold (1.06 log units) below what was measured; measured number above the stated range.
By their numbers in this assay, from the lowest: compound 3; then compounds 4, 1 and 2 (each within the scatter of the next, the first and the last beyond it).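

Unlike the earlier step, which changed only the pyridinyl group and stayed within the scatter, this one touches the six-membered aromatic ring of compound 3. In this assay, the added methoxy group gives an 11-fold higher number from compound 3 to compound 4 (1.06 log units; beyond the scatter), so this position is sensitive to this change in the strongest binder of the set. No evidence at hand explains the size of this step.

Going by these compounds, whether the loss follows from methoxy itself or from any group at this carbon remains open. A fluorine, a hydroxyl or an amine here, or methoxy on another carbon of this ring, would bear on that question.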